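The source may hold more compounds than are shown below. What is called first, only, known or untested is meant among the compounds shown, and "the series" means these compounds.

Compounds measured so far in a functional assay on HCC78 cells (Homo sapiens) for antiproliferative activity, read by MTT assay, with a stated time of 48 h; a higher number here means a weaker inhibitor, a lower number a stronger inhibitor:
compound 1 `Cc1ccc(CNC(=O)c2cccc(C(C)Oc3ccnc(Nc4cnn(C5CCN(C)CC5)c4)c3)c2)cc1`, 8100 nM
compound 2 `Cc1ccc(CNC(=O)c2cccc(C(C)Oc3ccnc(Nc4cnn(C)c4)c3)c2)cc1`, 8900 nM
compound 3 `Cc1ccc(CNC(=O)c2cccc(C(C)Oc3ccnc(NN4CCN(C)CC4)c3)c2)cc1`, 26200 nM

Compound 3 stands highest of these three numbers in this assay, its nearest neighbour being compound 2, and its step from compound 1 a 3.2-fold higher number from compound 1 to compound 3 (0.51 log units; beyond the scatter) and from compound 2 a 2.9-fold higher number from compound 2 to compound 3 (0.47 log units; beyond the scatter) both lying beyond the scatter. Compound 4 `Cc1ccc(CNC(=O)c2cccc(C(C)Oc3ccnc(Nc4cnn(CC(C)(C)O)c4)c3)c2)cc1` is the next compound to be measured. It differs from compound 3 in one place: 1-(2-hydroxy-2-methylpropyl)-1H-pyrazol-4-yl in place of 4-methylpiperazin-1-yl on a nitrogen on an aromatic ring.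

Within the data shown here, two measured steps bear on this change, both running in the opposite direction: the replacement of a pyrazolyl group by the piperazinyl group gave a 3.2-fold higher number from compound 1 to compound 3 (0.51 log units; beyond the scatter) and a 2.9-fold higher number from compound 2 to compound 3 (0.47 log units; beyond the scatter). Which substituent sits on the pyrazole nitrogen made little difference, since a 1.1-fold higher number from compound 1 to compound 2 (0.04 log units; within the scatter). Compound 4 carries a pyrazolyl group again, with a 2-hydroxy-2-methylpropyl substituent, so a reversal of those two steps is expected: a modest move to a lower number in this assay, roughly a 3.1-fold lower number from compound 3 to compound 4 (0.49 log units; beyond the scatter).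

On that basis compound 4 is estimated to give 8500 nM in this assay, with a range from 4000 nM to 18000 nM.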

Compound 4, half-maximal inhibitory concentration: 49700 nM
The estimate for compound 4 lay 5.8-fold (0.77 log units) below the measured number; measured number outside the range, above it.
By their numbers in this assay, from the lowest: compounds 1 and 2 (each within the scatter of the next); then compounds 3 and 4 (each within the scatter of the next).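

In this assay, a pyrazolyl group on this nitrogen does not by itself separate a compound from the 4-methylpiperazin-1-yl compound: a 1.9-fold higher number from compound 3 to compound 4 (0.28 log units; within the scatter) leaves the two indistinguishable, although compounds 1 and 2 had both stood apart from compound 3. The new result also shows that the substituent on the pyrazole nitrogen can matter, which the near-identical compounds 1 and 2 had not revealed: the 2-hydroxy-2-methylpropyl group gives a 5.6-fold higher number from compound 2 to compound 4 (0.75 log units; beyond the scatter) and a 6.1-fold higher number from compound 1 to compound 4 (0.79 log units; beyond the scatter), so methyl and 1-methylpiperidin-4-yl are matched with each other but not with this chain. No measurement here accounts for this difference.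

The compounds shown leave open whether the hydroxyl or the branched carbon chain of 2-hydroxy-2-methylpropyl goes with the higher number, a question that a plain 2-methylpropyl or an unbranched 2-hydroxyethyl group on the pyrazole nitrogen would address. They also leave open how an amine or a carboxylic acid at the end of such a chain would read in this assay.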